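The source may hold more compounds than are shown below. What is called first, only, known or untested is meant among the compounds shown, and "the series" means these compounds.

Compound 1 `Cc1ccc(NC(=O)CCN(Cc2ccc(C(=O)NO)cc2)C(=O)c2cc(C)cc(C)c2)cc1`: 31.1 nM
Compound 2 `Cc1cc(C)cc(C(=O)N(CCC(=O)NCc2ccccc2)Cc2ccc(C(=O)NO)cc2)c1`: 20.5 nM

In an assay on Sf9 cells for inhibition of protein deacetylase HDAC6 (Homo sapiens), read by fluorescence, with stated times of 90 min and 30 min (a lower number here means a stronger inhibitor, a higher number a weaker inhibitor), compound 2 gives 20.5 nM, the lowest of the two numbers, though compound 1 sits within the scatter of it, as a 1.5-fold lower number from compound 1 to compound 2 (0.18 log units; within the scatter) shows. Compound 3 `O=C(CCN(Cc1ccc(C(=O)NO)cc1)C(=O)c1ccccc1)NCc1ccccc1` differs from compound 2 in one place: phenyl in place of 3,5-dimethylphenyl on a carbonyl carbon. Going by the values given here, the single measured step altered the group on the amide-type nitrogen, a different part of the molecule, and stayed within the scatter, so no measured step bears directly on this change. The expected step is a 1.5-fold higher number from compound 2 to compound 3 (0.17 log units; within the scatter), nothing beyond the scatter. For compound 3 in this assay the estimate is 30 nM, between 12 nM and 75 nM.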

Compound 3, half-maximal inhibitory concentration: 12.5 nM
Estimate against measurement, compound 3: 2.4-fold (0.38 log units) above; the measured number falls inside the stated range.
By their numbers in this assay, from the lowest: compounds 3, 2 and 1 (each within the scatter of the next, the first and the last beyond it).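

Phenyl in place of 3,5-dimethylphenyl on the carbonyl carbon gives a 1.6-fold lower number from compound 2 to compound 3 (0.21 log units; within the scatter) in this assay. The methyl groups are therefore not required for a number of this size, at least with the benzyl group of compound 2 and compound 3 in place. Nothing measured here explains this result.

The compounds shown leave open how a chlorine atom or a methoxy group on this ring would read. Also open, on these data alone, is whether an amine on the ring would keep the number within the scatter.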